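Replacing the Propylcarbonyl Group of Compound 2

The source may hold more compounds than are shown below. What is called first, only, known or untested is meant among the compounds shown, and "the series" means these compounds.

In a functional assay on the whole organism with Mus musculus as the target (a higher number here means that more compound is needed for the effect, a lower number that less compound is needed), compound 2 `CCCC(=O)OC1CCN(c2ccc(-c3ccccc3Cl)nn2)CC1` gives 39 mg/kg. Its closest neighbour is compound 3 `CCCC(=O)OC1CCN(c2ccc(-c3ccc(Cl)cc3Cl)nn2)CC1`, which gives 31 mg/kg. The two sit level, as the step of a 1.3-fold lower number from compound 2 to compound 3 (0.10 log units; within the scatter) shows. Compound 1 `Cc1cc(Cl)ccc1-c1ccc(N2CCC(O)CC2)nn1` gives 10 mg/kg, the lowest number of the three and clearly lower than that of compound 2.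

The next compound, compound 4 `C/N=C(\S)OC1CCN(c2ccc(-c3ccccc3Cl)nn2)CC1`, changes compound 2 at a single place: a group of 4 heavy atoms (2 carbon, 1 nitrogen, 1 sulfur; no ring) in place of a group of 5 heavy atoms (4 carbon, 1 oxygen; no ring), on an oxygen on a saturated carbon. The propylcarbonyl group leaves, and the new group sits on the same oxygen.

For the measured compounds named here, no measured step covers this change. The only one available, a 1.3-fold lower number from compound 2 to compound 3 (0.10 log units; within the scatter), is a chloro in place of hydrogen on an aromatic carbon, so it bears on the question only indirectly. Compound 1, at 10 mg/kg, differs from compound 2 in more than one place, so it only hints at how far numbers can move in this assay.

With so little to go on, no shift beyond the scatter is expected, and the estimated step is a 1.3-fold lower number from compound 2 to compound 4 (0.11 log units; within the scatter). For compound 4 the estimated value is 30 mg/kg, with an expected range from 11 mg/kg to 85 mg/kg.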

Compound 4, dose for half-maximal effect: 20 mg/kg
Estimate against measurement, compound 4: 1.5-fold (0.18 log units) above; the measured number falls inside the stated range.
By their numbers in this assay, from the lowest: compounds 1, 4, 3 and 2 (each within the scatter of the next, the first and the last beyond it).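

In this assay, for the compounds shown here, the step of a 2.0-fold lower number from compound 2 to compound 4 (0.29 log units; within the scatter) is the first measured change at this oxygen on a saturated carbon; until now the only step lay on an aromatic carbon. It shows that the propylcarbonyl group can give way to a group of 4 heavy atoms holding nitrogen and sulfur, with 1 hydrogen-bond donor where the propylcarbonyl group has 0, while compound 2 and compound 4 stay level within the scatter. Nothing here explains why the two stay level.

The compounds shown leave open how an acetyl group, a longer chain such as hexanoyl, or a group carrying an amine would read on this same oxygen. They also leave open whether a chloro in place of hydrogen on the aromatic carbon, seen in a 1.3-fold lower number from compound 2 to compound 3 (0.10 log units; within the scatter), would give a similar step when added to compound 4.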